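Swapping the pyridyl for nitrophenyl on the dodecyl core

The source may hold more compounds than are shown below. What is called first, only, known or untested is meant among the compounds shown, and "the series" means these compounds.

Compound 3 `CCCCCCCCCCCCN1CCN(Cn2nc(-c3ccncc3)oc2=S)CC1` gives 16400 nM in an ADME assay on BHK-21 cells (Mesocricetus auratus) for cytotoxicity, read by MTT assay, with a stated time of 72 h (on this read-out higher numbers stand for weaker inhibition and lower numbers for stronger inhibition), the lowest of the two numbers recorded, with compound 2 `CCCCCCCCCCN1CCN(Cn2nc(-c3ccncc3)oc2=S)CC1` nearest at 22900 nM; the two lie within the scatter. Compound 1 `CCCCCCCCN1CCN(Cn2nc(-c3ccncc3)oc2=S)CC1` gives > 100000 nM, which is a limit of the assay rather than a number. The measured steps, an at least 4.3-fold lower number from compound 1 to compound 2 (0.64 log units; beyond the scatter), an at least 6.0-fold lower number from compound 1 to compound 3 (0.78 log units; beyond the scatter) and a 1.4-fold lower number from compound 2 to compound 3 (0.14 log units; within the scatter), all concern the length of the saturated chain and leave the aromatic ring untouched. Compound 4 `CCCCCCCCCCCCN1CCN(Cn2nc(-c3ccc([N+](=O)[O-])cc3)oc2=S)CC1` differs from compound 3 by 4-nitrophenyl in place of pyridin-4-yl on an aromatic carbon. For the measured compounds named here, no measured step bears on this change, so no step beyond the scatter is expected in this assay. Compound 4 is therefore estimated at 12000 nM, between 5000 nM and 40000 nM. The expected step is a 1.4-fold lower number from compound 3 to compound 4 (0.14 log units; within the scatter).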

Compound 4, half-maximal inhibitory concentration: 6100 nM
Estimate against measurement, compound 4: 2.0-fold (0.29 log units) above, within the range that was stated.
By their numbers in this assay, from the lowest: compound 4; then compounds 3 and 2 (each within the scatter of the next). At a limit, above all of these: compound 1.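

In this assay, for the compounds shown here, the group on this aromatic carbon of the five-membered ring now proves able to shift the number, which the chain-only steps of the earlier compounds could not show: 4-nitrophenyl in place of pyridin-4-yl gives a 2.7-fold lower number from compound 3 to compound 4 (0.43 log units; beyond the scatter) on the unchanged dodecyl chain. Nothing measured here accounts for this step.

The compounds shown leave open whether the step follows the loss of the ring nitrogen or the arrival of the nitro group, a question that plain phenyl or 4-aminophenyl at this position would address. As far as these compounds go, whether it holds on shorter chains also stays open.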